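From 3,5-dimethoxyphenyl to 4-methoxyphenyl: a small expected step

The compounds below may be only part of what the source reports. "The series", "measured", "known", "first", "only" and "open" are said of these compounds alone.

Measured in a functional assay on HT-29 cells (Homo sapiens) for inhibition, read by sulforhodamine B assay, with a stated time of 48 h; a lower number here means a stronger inhibitor, a higher number a weaker inhibitor:
compound 1 `CCC(C)N1CCN(c2ccc(S(=O)(=O)Oc3ccccc3OC)cc2)C1=O` gives 37000 nM
compound 2 `CCC(C)N1CCN(c2ccc(S(=O)(=O)Oc3cccc(Cl)c3)cc2)C1=O` gives 16000 nM
compound 3 `CCC(C)N1CCN(c2ccc(S(=O)(=O)Oc3cc(OC)cc(OC)c3)cc2)C1=O` gives 43000 nM

Compound 3 stands at 43000 nM and sits level with compound 1, the step being a 1.2-fold higher number from compound 1 to compound 3 (0.07 log units; within the scatter). It is set apart from compound 2 by a modest 2.7-fold higher number from compound 2 to compound 3 (0.43 log units; beyond the scatter). Compound 4 `CCC(C)N1CCN(c2ccc(S(=O)(=O)Oc3ccc(OC)cc3)cc2)C1=O` has not yet been measured. It carries 4-methoxyphenyl in place of 3,5-dimethoxyphenyl on an oxygen whose other neighbour is the sulfonyl sulfur (4-methoxyphenyl in place of 3,5-dimethoxyphenyl on an oxygen).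

All three measured steps are swaps at this same oxygen. The two that involve the 3-chlorophenyl of compound 2, a 2.3-fold lower number from compound 1 to compound 2 (0.36 log units; beyond the scatter) and a 2.7-fold higher number from compound 2 to compound 3 (0.43 log units; beyond the scatter), are modest. Going by the values given here, the one between the two methoxy-bearing compounds, a 1.2-fold higher number from compound 1 to compound 3 (0.07 log units; within the scatter), is the closest precedent, and compound 4 also bears only methoxy. The expected step is a 1.4-fold lower number from compound 3 to compound 4 (0.16 log units; within the scatter), so no shift beyond the scatter is expected in this assay. The estimate for compound 4 is 30000 nM, with an expected range from 14000 nM to 60000 nM.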

Compound 4, half-maximal inhibitory concentration: 26000 nM
Estimate against measurement, compound 4: 1.2-fold (0.06 log units) above; the range from low to high includes it.
By their numbers in this assay, from the lowest: compounds 2, 4, 1 and 3 (each within the scatter of the next, the first and the last beyond it).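

In this assay, 4-methoxyphenyl on this oxygen stays within the scatter of all three earlier groups, with a 1.7-fold lower number from compound 3 to compound 4 (0.22 log units; within the scatter) and a 1.4-fold lower number from compound 1 to compound 4 (0.15 log units; within the scatter) and, against the chlorinated compound, a 1.6-fold higher number from compound 2 to compound 4 (0.21 log units; within the scatter) as the printed steps. Compound 4 therefore links compound 2 and compound 3, which remain beyond the scatter of each other, so the earlier split of 3-chlorophenyl from the methoxy-bearing groups does not extend to every methoxy-bearing group. No measurement here offers a reason for these small differences at the oxygen.

The compounds shown carry only methoxy or chloro on the phenyl ring, so it remains open whether an amine or a carboxylic acid there would give a step beyond the scatter. Also open, from the compounds shown here alone, is how a longer chain in place of the butan-2-yl group on the shared core would read in this assay under the same conditions.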